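Swapping the cyano of compound 1 for benzyloxy

This account rests on a few compounds, and the source may have more. Where it says the series, first, only, none or still open, it means among the compounds named here.

Going by the values given here, compound 1, `N#Cc1cc(C#N)cc(-n2nnc(-c3ccccn3)n2)c1`, is one of two compounds measured in a functional assay with metabotropic glutamate receptor 5 (Rattus norvegicus) as the target (on this read-out higher numbers stand for weaker inhibition and lower numbers for stronger inhibition), where compound 1 gives 34 nM. Its companion compound 2, `N#Cc1cc(-n2nnc(-c3ccccn3)n2)cc([N+](=O)[O-])c1`, gives 42 nM in this assay. The two numbers differ by a 1.2-fold higher number from compound 1 to compound 2 (0.09 log units; within the scatter), so on the numbers shown compound 1 has the lower value of the pair, but the gap to compound 2 does not exceed the scatter, and the two cannot be ordered.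

Compound 3, `N#Cc1cc(OCc2ccccc2)cc(-n2nnc(-c3ccccn3)n2)c1`, has not yet been measured in this assay. Relative to compound 1 the change is benzyloxy in place of cyano on an aromatic carbon. Among the compounds with values here, the only step known on this shared core, from compound 1 to compound 2, exchanged cyano for nitro at the same kind of position and stayed within the scatter, so it shows that this position tolerates a small substituent swap; it says little about a group as large as benzyloxy. Without a closer precedent, compound 3 is expected to show a step of a 5.0-fold higher number from compound 1 to compound 3 (0.70 log units; beyond the scatter) toward a higher number, with a wide range. The estimate for compound 3 in this assay is 170 nM, between 40 nM and 1500 nM.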

Compound 3, half-maximal inhibitory concentration: > 1000 nM
Compound 3 gave a limit, no number; the forecaster's own chance of this, stated with the estimate: 10%; at least 5.8-fold (0.76 log units) between middle value and limit.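

In this assay compound 3 gives > 1000 nM, which is a limit of the assay and not a number: the limit of > 1000 nM in this assay, at which 1 of the 3 values shown sits. Even so, the steps can be read as lower bounds, and benzyloxy in place of cyano gives an at least 29-fold higher number from compound 1 to compound 3 (1.46 log units; beyond the scatter), while benzyloxy in place of nitro gives an at least 23-fold higher number from compound 2 to compound 3 (1.37 log units; beyond the scatter). The earlier pair showed only that cyano and nitro on this aromatic carbon cannot be told apart, whereas this result shows that the position does not accept every group, since benzyloxy, which brings a six-membered aromatic ring of carbon only, lies beyond the scatter from both.

The compounds shown do not separate the part played by the oxygen link from that of the added ring, so a methoxy group, or a phenyl ring set directly on this carbon, would be needed to tell the two apart. From the compounds shown here alone, it also remains open how an amine or a carboxylic acid at this position would read out, and whether any group here can give a lower number than the cyano of compound 1.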